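Replacing the bromo group of compound 3

The source may hold more compounds than are shown below. What is called first, only, known or untested is meant among the compounds shown, and "the series" means these compounds.

Measured in a functional assay on SK-OV-3 cells (Homo sapiens) for antiproliferative activity, read by MTT assay, with a stated time of 72 h; a higher number here means a weaker inhibitor, a lower number a stronger inhibitor:
Compound 1 `CC(C)(C)NC(=O)CCc1cccc2c1B(O)OC2` gives > 100000 nM as a limit of the assay
Compound 2 `O=C(CCc1cccc2c1B(O)OC2)NC1CCCCC1` gives > 100000 nM as a limit of the assay
Compound 3 `O=C(CCc1cccc2c1B(O)OC2)Nc1ccc(Br)cc1` gives 9200 nM as a number

Compound 3 alone has a number, since compound 1 and compound 2 stand at a limit (the limit of > 100000 nM in this assay, at which 2 of the 3 values shown sit). Compound 4 `CC(C)(C)OC(=O)Nc1ccc(NC(=O)CCc2cccc3c2B(O)OC3)cc1` carries (tert-butoxycarbonyl)amino in place of bromo on an aromatic carbon. For the measured compounds named here, no measured step changes this group. The nearest are an at least 10-fold lower number from compound 1 to compound 3 (1.03 log units; beyond the scatter) and an at least 10-fold lower number from compound 2 to compound 3 (1.03 log units; beyond the scatter) where the whole amide substituent changes. Compound 4 keeps the aromatic ring that compound 3 gained in those steps, so only a moderate rise in the number is expected in this assay. The expected change is a 1.6-fold higher number from compound 3 to compound 4 (0.21 log units; within the scatter) by this estimate. For compound 4 the estimated value is 15000 nM with an expected range from 4000 nM to 60000 nM in this reading.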

Compound 4, half-maximal inhibitory concentration: > 100000 nM
Compound 4 ended at the assay's limit (the forecaster's own chance of this, stated with the estimate: 15%); at least 6.6-fold (0.82 log units) between middle value and limit.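

In this assay, (tert-butoxycarbonyl)amino in place of bromo gives an at least 10-fold higher number from compound 3 to compound 4 (1.03 log units; beyond the scatter). The earlier steps shown here changed the whole amide substituent, whereas this one shows that the aromatic ring alone does not secure a measurable value: the group on the aromatic carbon para to a large group also counts. Compound 4 therefore shares its limit with compound 1 and compound 2: the limit of > 100000 nM in this assay, at which 3 of the 4 values shown sit.

The compounds shown leave open whether bromo itself is needed, or whether a free amine or chlorine at this position would keep a measurable value. As far as these compounds go, how far compound 4 lies past its limit also stays unknown.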